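The compounds below may be only part of what the source reports. "The series", "measured", "known", "first", "only" and "open" are said of these compounds alone.

Three compounds built on one shared core were tested in a functional assay on MCF7 cells (Homo sapiens) for cytotoxicity, read by MTT assay, with a stated time of 48 h; a lower number here means a stronger inhibitor, a higher number a weaker inhibitor. Compound 1 `COc1cc(-c2nnc(SCc3ccccc3Cl)n2/N=C/c2ccccc2)cc(OC)c1OC` gives > 200000 nM, which is a limit of the assay and not a number. Compound 2 `COc1ccc(/C=N/n2c(SC)nnc2-c2cc(OC)c(OC)c(OC)c2)c(OC)c1` likewise reaches only the limit > 200000 nM. Compound 3 `COc1ccc(/C=N/n2c(SCc3ccc(F)cc3)nnc2-c2cc(OC)c(OC)c(OC)c2)c(OC)c1` also sits at the limit > 200000 nM. Going by the values given here, the step that the two limits leave unreadable from compound 2 to compound 3 therefore cannot be read, and the only evidence, (the limit of > 200000 nM in this assay, at which 3 of the 3 values shown sit), shows every measured value at the same limit. Compound 4 `COc1ccc(/C=N/n2c(SCc3ccccc3Cl)nnc2-c2cc(OC)c(OC)c(OC)c2)c(OC)c1` differs from compound 3 by 2-chlorophenyl in place of 4-fluorophenyl on a saturated chain carbon bound to a sulfur. Compound 1 already carries the 2-chlorobenzyl group yet stands at the limit. The expected step is therefore a number no higher from compound 3 to compound 4 (the limit leaves the size open), nothing beyond the scatter. Compound 4 is estimated at 200000 nM, within 100000 nM to 400000 nM, most likely again only a limit.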

Compound 4, half-maximal inhibitory concentration: 63700 nM
Compound 4: the middle estimate sits 3.1-fold (0.50 log units) above what was measured; measured number outside the range, below it.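

In this assay, the 2-chlorobenzyl group yields a readable number only in the company of the 2,4-dimethoxyphenyl group. Changing the group on a saturated chain carbon bound to a sulfur gives an at least 3.1-fold lower number from compound 3 to compound 4 (0.49 log units; beyond the scatter) and an at least 3.1-fold lower number from compound 2 to compound 4 (0.49 log units; beyond the scatter), while changing the group on a carbon with a double bond to nitrogen gives an at least 3.1-fold lower number from compound 1 to compound 4 (0.49 log units; beyond the scatter). Among the compounds shown, only this pairing leaves the limit: the limit of > 200000 nM in this assay, at which 3 of the 4 values shown sit.

As far as these compounds go, whether a bromophenyl or a pyridyl group on that chain carbon would lower the number further stays open. From the compounds shown here alone, the full size of all three steps also stays open, each starting from a limit.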